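Trading 3-Bromophenyl for 4-Hydroxyphenyl

The compounds below may be only part of what the source reports. "The series", "measured", "known", "first", "only" and "open" are said of these compounds alone.

Among the measured compounds shown here, in a functional assay (on this read-out higher numbers stand for weaker inhibition and lower numbers for stronger inhibition), compound 1 `CC(C)=CCOc1cc(O)c2c(c1)OC(c1ccccc1)CC2=O` gives 7320 nM and compound 2 `CC(C)=CCOc1cc(O)c2c(c1)OC(c1cccc(Br)c1)CC2=O` gives 4040 nM, so compound 2 stands within the scatter of its only measured neighbour. Compound 3 `CC(C)=CCOc1cc(O)c2c(c1)OC(c1ccc(O)cc1)CC2=O` brings a new change, 4-hydroxyphenyl in place of 3-bromophenyl on a saturated ring carbon. For the measured compounds named here, the one measured step, a 1.8-fold lower number from compound 1 to compound 2 (0.26 log units; within the scatter), is bromo in place of hydrogen on an aromatic carbon and offers only a weak guide. No shift beyond the scatter is therefore expected in this assay, and the expected step is a 1.2-fold higher number from compound 2 to compound 3 (0.09 log units; within the scatter). For compound 3 the estimated value is 5000 nM, with an expected range of 2000 nM to 12500 nM.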

Compound 3, half-maximal inhibitory concentration: 5340 nM
Compound 3: the middle estimate sits 1.1-fold (0.03 log units) below what was measured; low and high end bracket the measured number.
By their numbers in this assay, from the lowest: compounds 2, 3 and 1 (each within the scatter of the next).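

In this assay, 4-hydroxyphenyl in place of 3-bromophenyl on a saturated ring carbon gives a 1.3-fold higher number from compound 2 to compound 3 (0.12 log units; within the scatter), and adding only a hydroxy group gives a 1.4-fold lower number from compound 1 to compound 3 (0.14 log units; within the scatter). At this place next to the ring oxygen, then, phenyl, 3-bromophenyl and 4-hydroxyphenyl cannot be told apart on this read-out, even though only 4-hydroxyphenyl carries a hydrogen-bond donor. No measurement here bears on the reason for this flat result. From the compounds shown here alone, whether an amine or a carboxylic acid on this aromatic ring, or a longer chain in its place, would move the number beyond the scatter remains open.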